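Trimming the amine chain of compound 3 by one carbon

The source may report more compounds than this note shows. Statements on the series, on what has been measured and on what is new or still open speak of the compounds shown alone.

This study measures how much of each compound is tolerated by a mouse hippocampal preparation, in an ADME assay on Hippocampus (Mus musculus), read by MTT assay; a higher number here means that more compound is tolerated, a lower number that less compound is tolerated. Compound 3, `CC(C)CNc1c(O)cc(O)c2c(=O)cc(-c3ccccc3)oc12`, gives 12 uM. Compound 2, `CC(C)CCNc1c(O)cc(O)c2c(=O)cc(-c3ccccc3)oc12`, gives 12 uM, and compound 1, `CCCNc1c(O)cc2oc(-c3ccccc3)cc(=O)c2c1O`, gives 10 uM. Compound 3 therefore stands level with compound 2, the two of them at the top of the three numbers, and compound 1 sits only marginally lower, within the usual scatter.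

The next compound, compound 4, `CCCNc1c(O)cc(O)c2c(=O)cc(-c3ccccc3)oc12`, differs from compound 3 by hydrogen in place of methyl on a saturated chain carbon bound to two saturated chain carbons. Put another way, the chain on the aromatic nitrogen goes from isobutylamino to propylamino.

Within the data shown here, one measured step bears on this: no change at the digits printed from compound 2 to compound 3 (within the scatter). That step also trimmed the same chain by a single carbon and left this assay unchanged. Compound 1, which carries a propylamino chain on a core arranged differently, likewise gives a number close to the others. Among the measured compounds shown here, nothing among the measured compounds points to a tolerance that is sensitive to the length of this chain.

The expected step for compound 4 in this assay is therefore a 1.1-fold lower number from compound 3 to compound 4 (0.04 log units; within the scatter), no change beyond the scatter. Compound 4 is estimated to give 11 uM, within a range from 6 uM to 22 uM.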

Compound 4, half-maximal toxic concentration: 14 uM
Compound 4: middle estimate off by 1.3-fold (0.10 log units), on the low side; measured number inside the range.
By their numbers in this assay, from the lowest: compounds 1, 2, 3 and 4 (each within the scatter of the next).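

Dropping the methyl turns the isobutylamino chain into propylamino, and in this assay this gives a 1.2-fold higher number from compound 3 to compound 4 (0.07 log units; within the scatter) and so stays within the scatter. Among these compounds, this is the first direct look at the branch on this chain carbon, and it shows that the branched and the straight chain cannot be told apart here. The comparison with the longer branched chain of compound 2 reads the same way, with a 1.2-fold higher number from compound 2 to compound 4 (0.07 log units; within the scatter) also within the scatter, so the three chains on the shared core give one flat picture in this assay, and nothing measured here offers a reason for it.

Going by these compounds, all three of these chains are small saturated carbon chains on the same nitrogen, so it remains open whether the tolerated amount would hold for a much longer chain, a cyclohexyl ring, or a chain ending in a carboxylic acid. On these data alone, it is equally open whether a plain amine, with no carbon chain on the nitrogen at all, would stay level with these compounds or move clearly away from them.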